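Ester Side-Chain Swaps on a Shared Core

The compounds below may be only part of what the source reports. "The series", "measured", "known", "first", "only" and "open" are said of these compounds alone.

Compound 1 `C/C=C1/[C@H](O[C@@H]2O[C@H](CO)[C@@H](O)[C@H](O)[C@H]2O)OC=C(C(=O)OC)[C@H]1CC(=O)OCc1ccco1` gives in a functional assay on SK-BR-3 cells (Homo sapiens) for antiproliferative activity, read by MTT assay, with a stated time of 72 h (a lower number here means a stronger inhibitor, a higher number a weaker inhibitor), only a limit, > 15000 nM.
Compound 2 `C/C=C1/[C@H](O[C@@H]2O[C@H](CO)[C@@H](O)[C@H](O)[C@H]2O)OC=C(C(=O)OC)[C@H]1CC(=O)OCCCc1ccc(OC)c(OC)c1` gives in this assay only a limit, > 20000 nM.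
Compound 3 `C/C=C1/[C@H](O[C@@H]2O[C@H](COC(C)=O)[C@@H](OC(C)=O)[C@H](OC(C)=O)[C@H]2OC(C)=O)OC=C(C(=O)OC)[C@H]1CC(=O)SCCc1ccccc1` gives in this assay only a limit, > 15000 nM.

Compound 1 thus stands at a limit, and the two further values are limits as well, so no order among the three can be read. Going by the values given here, the one measured step at the same place is a step that the two limits leave unreadable from compound 1 to compound 2; the values behind it are the limit of > 15000 nM in this assay, at which 2 of the 3 values shown sit, and (the limit of > 20000 nM in this assay, at which 1 of the 3 values shown sits). Compound 4 `C/C=C1/[C@H](O[C@@H]2O[C@H](CO)[C@@H](O)[C@H](O)[C@H]2O)OC=C(C(=O)OC)[C@H]1CC(=O)OCCc1ccc(OC)cc1` differs from compound 1 by 4-methoxybenzyl in place of furan-2-yl on a saturated chain carbon bound to an oxygen next to a carbonyl group. Among the compounds with values here, with the only comparable step unreadable, no step beyond the scatter is expected in either direction. Compound 4 is therefore expected to give 20000 nM, with a range from 8000 nM to 60000 nM. This estimate means an expected step that the limit leaves unreadable from compound 1 to compound 4.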

Compound 4, half-maximal inhibitory concentration: > 20000 nM
Compound 4: only a limit was reported; the forecaster's own chance of this, stated with the estimate: 85%; the middle value lies on the limit itself.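

Compound 4 gives only a limit, as do compound 1 and compound 2, so the steps to compound 4 from compound 1 and compound 2 cannot be read. The compounds shown leave open which of these side chains, if any, gives a measurable potency in this assay.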